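Oxan-4-yl for 4-hydroxycyclohexyl on compound 1

A few compounds are considered here, and "the series" means these few. Any claim that something is new, unique, unknown or untested is made for them only; others in the source may bear on it.

In an in vivo ADME assay on the whole organism (strain Sprague-Dawley) for metabolic stability, with Rattus norvegicus as the target (on this read-out lower numbers stand for a shorter-lived compound and higher numbers for a longer-lived compound), compound 1 `N#Cc1c(-c2ccc3c(ccn3[C@H]3CC[C@H](O)CC3)c2)ccn2c(CC(F)(F)F)cnc12` gives 2.8 h and compound 2 `O[C@H]1CC[C@H](n2ccc3cc(-c4ccn5c(CC(F)(F)F)cnc5c4Cl)ccc32)CC1` gives 4.3 h. Among the compounds with values here, these are the only two numbers, and they do not separate: the step, chloro in place of cyano on an aromatic carbon, is a 1.5-fold higher number from compound 1 to compound 2 (0.19 log units; within the scatter).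

Compound 3 `N#Cc1c(-c2ccc3c(ccn3C3CCOCC3)c2)ccn2c(CC(F)(F)F)cnc12` keeps the core of compound 1 and changes one group, oxan-4-yl in place of 4-hydroxycyclohexyl on an aromatic nitrogen. Within the data shown here, no measured step touches that nitrogen. Among the measured compounds shown here, the single step at hand lies elsewhere on the core and bears only indirectly, as a sign of how little the number has moved so far. No shift beyond the scatter is therefore expected in this assay, and no firm direction. The estimated step is a 1.1-fold lower number from compound 1 to compound 3 (0.05 log units; within the scatter). For compound 3 the expected value is 2.5 h, with an estimated range from 1.2 h to 5 h.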

Compound 3, half-life: 0.92 h
Estimate against measurement, compound 3: 2.7-fold (0.43 log units) above; measured number outside the range, below it.
By their numbers in this assay, from the lowest: compound 3; then compounds 1 and 2 (each within the scatter of the next).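

Within the data shown here, the substituent on the aromatic nitrogen is the first place where this assay separates two compounds beyond the scatter: a 3.0-fold lower number from compound 1 to compound 3 (0.48 log units; beyond the scatter). The chloro-for-cyano change on the aromatic carbon did not separate compound 1 from compound 2, so this nitrogen substituent is the only change shown so far with a readable effect on this read-out. The change gives up the hydrogen-bond donor and the defined stereocentres of 4-hydroxycyclohexyl, but no measurement on these compounds accounts for the shift.

With one pair, the hydroxyl on the carbocycle and the oxygen within the oxan-4-yl ring cannot be told apart as the feature that matters. Also open, as far as these compounds go, are how a piperidin-4-yl group on the same nitrogen would read, and whether chloro in place of cyano on compound 3 would give the same result as on compound 1.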